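Metabolic stability notes: amide cap variation on compound 2

The source may hold more compounds than are shown below. What is called first, only, known or untested is meant among the compounds shown, and "the series" means these compounds.

Measured compounds:
compound 1 `CCn1ncc(-c2nc3c(N4CCC(n5c(=O)[nH]c6ncccc65)CC4)ncnc3n2C)c1C` — 60 mL/min/kg
compound 2 `CCn1ncc(-c2nc3c(O[C@H]4CCN(C(=O)C5CC5)C4)ncnc3n2C)c1C` — 98 mL/min/kg

In an ADME assay on the whole organism (Rattus norvegicus, strain Wistar Han) for metabolic stability (a lower number here means slower removal, a higher number faster removal of the compound), compound 1 gives 60 mL/min/kg and compound 2 gives 98 mL/min/kg. Compound 2 gives the higher of the two numbers, but the gap to compound 1 lies within the usual scatter of this assay, so the two cannot be separated on these data. No single-point comparison between measured compounds exists in this set.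

The next compound, compound 3 `CCn1ncc(-c2nc3c(O[C@H]4CCN(C(=O)C5CCOCC5)C4)ncnc3n2C)c1C`, differs from compound 2 in one place: oxan-4-yl in place of cyclopropyl on a carbonyl carbon. The pair shares the rest of its structure.

For the measured compounds named here, with only two measured numbers, close together, there is no basis for expecting a step beyond the scatter. Compound 3 is therefore expected to sit near compound 2, with a 1.2-fold lower number from compound 2 to compound 3 (0.06 log units; within the scatter) as the estimated step in this assay, in no clear direction. The estimate for compound 3 is 85 mL/min/kg, with a range from 45 mL/min/kg to 150 mL/min/kg.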

Compound 3, clearance: 126 mL/min/kg
Estimate against measurement, compound 3: 1.5-fold (0.17 log units) below, and the stated range covers the measured number.
By their numbers in this assay, from the lowest: compounds 1, 2 and 3 (each within the scatter of the next, the first and the last beyond it).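

For the compounds shown here, the first one-place comparison concerns the group on the carbonyl carbon: in this assay, oxan-4-yl in place of cyclopropyl gives a 1.3-fold higher number from compound 2 to compound 3 (0.11 log units; within the scatter). The two groups therefore cannot be separated at this position, even though oxan-4-yl brings a larger ring and a hydrogen-bond acceptor to the same carbonyl carbon. No measurement in hand bears on this result.

Both groups shown on this carbonyl carbon are non-aromatic rings, so it remains open whether an open chain such as methoxyethyl, or an amine such as dimethylamino, would give a step beyond the scatter in this assay. On these data alone, it also remains open whether a one-place change elsewhere on the shared core would give such a step.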